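This account rests on a few compounds, and the source may have more. Where it says the series, first, only, none or still open, it means among the compounds named here.

Of the compounds shown here, three have so far been read in an in vitro ADME assay on microsomes from liver (Homo sapiens) for metabolic stability; on this read-out higher numbers stand for fast clearance and lower numbers for slow clearance. Compound 1 `Cc1cnc(NC(=O)c2cc(Oc3cnc(C(=O)N(C)C)cn3)c3cc(C)nn3c2)cn1` gives a true number, 13.7 mL/min/kg. Compound 2 `Cc1cnc(NC(=O)c2cc(Oc3ccc(S(C)(=O)=O)cc3)c3cn(C)nc3c2)cn1` gives < 8 mL/min/kg, which is a limit of the assay and not a number. Compound 3 `CCS(=O)(=O)c1ccc(Oc2cc(C(=O)Nc3cnc(C)cn3)cc3nn(C)cc23)cc1` gives < 8 mL/min/kg, and this too is only a limit. On these data alone, compound 3 therefore stands at the limit of < 8 mL/min/kg in this assay, at which 2 of the 3 values shown sit, and its exact place on the scale stays unknown.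

Compound 4 `Cc1cnc(NC(=O)c2cc(Oc3ccc(S(=O)(=O)N(C)C)cc3)c3cn(C)nc3c2)cn1` differs from compound 3 at one place, the group on the sulfonyl sulfur, where ethylsulfonyl becomes dimethylsulfamoyl: dimethylamino in place of ethyl on a sulfonyl sulfur. Among the compounds with values here, the one measured step at this same sulfur is a step that the two limits leave unreadable from compound 2 to compound 3. Within the data shown here, it offers no size to carry over, and no measured pair shows dimethylamino in place of ethyl. The expectation therefore rests on compound 3 at < 8 mL/min/kg, a limit, and no step beyond the usual scatter is expected in this assay. As far as these compounds go, the change remains untested, so the expected range stays wider on the upper side. The estimated step is a step that the limit leaves unreadable from compound 3 to compound 4. For compound 4 the expected clearance is 7 mL/min/kg, with an estimated range from 4 mL/min/kg to 13 mL/min/kg.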

Compound 4, clearance: < 8 mL/min/kg
Compound 4 ended at the assay's limit; the forecaster's own chance of this, stated with the estimate: 65%; the middle value is on the limit's open side.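

No step can be read from compound 3 to compound 4 or from compound 2 to compound 4, because all three compounds give a limit and not a number: the limit of < 8 mL/min/kg in this assay, at which 3 of the 4 values shown sit.

The compounds shown leave open how the true clearances of compound 2, compound 3 and compound 4 compare, and so whether dimethylamino in place of ethyl on a sulfonyl sulfur changes clearance at all.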